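Three Near-Identical Readings Set the Stage for Compound 4

The source may report more compounds than this note shows. Statements on the series, on what has been measured and on what is new or still open speak of the compounds shown alone.

Compound 1 `COc1cc(Cl)cc(-c2nn(-c3cccc(NC(=O)Nc4ccc(Cl)c(C(F)(F)F)c4)c3)cc2-c2ccncc2)c1`, compound 2 `COc1cc(Cl)cc(-c2nn(-c3cccc(NC(=O)Nc4ccc(Cl)c(Cl)c4)c3)cc2-c2ccncc2)c1` and compound 3 `COc1cc(Cl)cc(-c2nn(-c3cccc(NC(=O)Nc4cccc(C(F)(F)F)c4)c3)cc2-c2ccncc2)c1` share one core and differ only in the group carried on the amide-type nitrogen. In a functional assay on RPMI-8226 cells (Homo sapiens) for inhibition, read by sulforhodamine B assay, with a stated time of 48 h, tested at 0.1 uM (on this read-out lower numbers stand for a stronger effect and higher numbers for a weaker effect at the one concentration tested), compound 1 gives 100%, compound 2 gives 100% and compound 3 gives 98%. Compound 3 has the lowest of the three numbers, yet the gaps are a number 2 percentage points lower from compound 1 to compound 3 (within the scatter) and a number 2 percentage points lower from compound 2 to compound 3 (within the scatter), so all three values sit together within the scatter, and no order among them can be read.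

Compound 4 `COc1cc(Cl)cc(-c2nn(-c3cccc(NC(=O)c4cccc(C(F)(F)F)c4)c3)cc2-c2ccncc2)c1` differs from compound 3 in a single place: 3-(trifluoromethyl)phenyl in place of (3-(trifluoromethyl)phenyl)amino on a carbonyl carbon. None of the three measured steps touches the carbonyl carbon itself; they alter only the substituents on the outer aromatic ring, and each stayed within the scatter (no change at the digits printed from compound 1 to compound 2 (within the scatter), a number 2 percentage points lower from compound 1 to compound 3 (within the scatter), a number 2 percentage points lower from compound 2 to compound 3 (within the scatter)). Nothing in the data therefore indicates a shift beyond the scatter for compound 4, and a step of a number 1 percentage points lower from compound 3 to compound 4 (within the scatter) in this assay is expected. Compound 4 is accordingly estimated to give 97%, with a range from 85% to 105%.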

Compound 4, a percentage reported as activity, at one concentration (the size of the read-out at that concentration, not a potency): 97%
Beside the measured number, compound 4's estimate shows no gap at the digits printed, within the range that was stated.
By their numbers in this assay, from the lowest: compounds 4, 3, 1 and 2 (each within the scatter of the next).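

Unlike the earlier steps, which altered only the substituents on the outer aromatic ring, this change reaches the link to that ring: in this assay, replacing (3-(trifluoromethyl)phenyl)amino with 3-(trifluoromethyl)phenyl on the carbonyl carbon removes the nitrogen and its hydrogen-bond donor, and the result is a number 1 percentage points lower from compound 3 to compound 4 (within the scatter). The two steps that change the link and the ring substituents together are also small, with a number 3 percentage points lower from compound 2 to compound 4 (within the scatter) and a number 3 percentage points lower from compound 1 to compound 4 (within the scatter), so at this one concentration the read-out does not separate the amino-linked compounds from compound 4, even though the hydrogen-bond donor of the leaving group is absent from the group that enters. No evidence is available that bears on why this position tolerates the change in this read-out.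

The compounds shown leave open whether a different group on this carbonyl carbon, such as an amine, a carboxylic acid or a longer alkyl chain, would give a step beyond the scatter. They also leave open whether compound 3 and compound 4 would stay together at other concentrations, since a single-concentration reading gives no potency.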